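Swapping the Side Chain on the Shared Core

The source may report more compounds than this note shows. Statements on the series, on what has been measured and on what is new or still open speak of the compounds shown alone.

Compound 1 `O=C1c2c[n+]([O-])c3ccccc3c2C(=O)c2c1c1ccccc1n2Cc1cn([C@@H]2C[C@H](O)[C@@H](CO)O2)nn1`: 20 nM
Compound 2 `O=C1c2c[n+]([O-])c3ccccc3c2C(=O)c2c1c1ccccc1n2Cc1cn(C[C@H](O)CO)nn1`: 350 nM

In a functional assay on A-375 cells (Homo sapiens) for cytotoxicity, read by MTT assay, with a stated time of 72 h (a lower number here means a stronger inhibitor, a higher number a weaker inhibitor), compound 1 gives 20 nM and compound 2 gives 350 nM, so compound 2 stands highest of the two numbers. Going by the values given here, the single measured step, an 18-fold higher number from compound 1 to compound 2 (1.24 log units; beyond the scatter), altered only the group on an aromatic nitrogen and was large. Compound 3 `CCCN1CCN(CCCCn2c3c(c4ccccc42)C(=O)c2c[n+]([O-])c4ccccc4c2C3=O)CC1` goes further: 3-(4-propylpiperazin-1-yl)propyl in place of 1-(2,3-dihydroxypropyl)-1H-1,2,3-triazol-4-yl on a saturated chain carbon bound to an aromatic nitrogen. Among the compounds with values here, no measured step tests a change of this kind, so its direction is open, and a wide range is warranted. The estimate for compound 3 is 200 nM, between 40 nM and 1000 nM, and the expected step is a 1.8-fold lower number from compound 2 to compound 3 (0.24 log units; within the scatter).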

Compound 3, half-maximal inhibitory concentration: 870 nM
The estimate for compound 3 lay 4.4-fold (0.64 log units) below the measured number, within the range that was stated.
By their numbers in this assay, from the lowest: compound 1; then compound 2; then compound 3.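

Putting 3-(4-propylpiperazin-1-yl)propyl in place of 1-(2,3-dihydroxypropyl)-1H-1,2,3-triazol-4-yl gives a 2.5-fold higher number from compound 2 to compound 3 (0.40 log units; beyond the scatter) in this assay and counts as a modest change. The entering group has no five-membered aromatic ring and no hydrogen-bond donors, so compound 3 shows that cytotoxicity at this position does not require either feature. Nothing measured here explains the shift. The compounds shown do not separate the effect of the piperazine ring from that of the chain carrying it. A morpholine ring in place of the 4-propylpiperazine, or a plain butyl chain, would leave that question open no longer.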